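Swapping the side-chain amine for a hydroxyl

The compounds below may be only part of what the source reports. "The series", "measured", "known", "first", "only" and "open" are said of these compounds alone.

Of the compounds shown here, three of a shared core have been measured in a functional assay on ileum for inhibition of histamine H1 receptor (Cavia porcellus); a lower number here means a stronger inhibitor, a higher number a weaker inhibitor. Compound 1, `CCNCCn1c(N2CCN(C)CC2)nc2ccccc21`, gives 290 nM in this assay, the highest of the two numbers reported. Compound 3, `CCCCCN1CCN(c2nc3ccccc3n2CCOCC)CC1`, gives 30 nM in this assay, a value beyond the usual scatter from that of compound 1. Compound 2, `CCOCCn1c(N2CCN(C(c3ccccc3)c3ccccc3)CC2)nc2ccccc21`, reaches only a limit in this assay, recorded as > 3000 nM, so no number is known for it; (the limit of > 3000 nM in this assay, at which 1 of the 3 values shown sits).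

The new compound 4, `CN1CCN(c2nc3ccccc3n2CCO)CC1`, differs from compound 1 in one place: hydroxy in place of ethylamino on a saturated chain carbon, two bonds along the chain from an aromatic nitrogen.

Among the measured compounds shown here, no pair of measured compounds differs in exactly this way, so the size of the step must be guessed from the structural change alone. A step toward a higher number in this assay is expected, beyond the scatter but not extreme, given that the side chain shortens and the nitrogen on it disappears. The expected step is a 3.1-fold higher number from compound 1 to compound 4 (0.49 log units; beyond the scatter). Compound 4 is therefore estimated to give about 900 nM in this assay, with a likely range from 250 nM to 3500 nM.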

Compound 4, half-maximal inhibitory concentration: 410 nM
For compound 4 the middle estimate is 2.2-fold (0.34 log units) above the measured one; the range from low to high includes it.
By their numbers in this assay, from the lowest: compound 3; then compounds 1 and 4 (each within the scatter of the next). At a limit, above all of these: compound 2.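

In this assay, putting hydroxy in place of ethylamino on a saturated chain carbon, two bonds along the chain from an aromatic nitrogen, gives a 1.4-fold higher number from compound 1 to compound 4 (0.15 log units; within the scatter). At this position, then, the two groups cannot be told apart in this assay, and the full ethylamino group is not required for a value of this size, at least in this pair. Nothing measured here explains why the two groups match.

Going by these compounds, it remains open what a carboxylic acid, a dimethylamino group or a longer chain ending in hydroxy would give at this same place. It is also unknown whether hydroxy and ethylamino would still match in compounds that differ from this pair elsewhere on the shared core.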